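This account rests on a few compounds, and the source may have more. Where it says the series, first, only, none or still open, it means among the compounds named here.

Compound 1 `COc1cc(-c2nn(-c3cccc(NC(=O)Nc4ccc(Cl)c(C(F)(F)F)c4)c3)cc2-c2ccncc2)ccc1Cl` gives 1320 nM in a functional assay on Hs-578T cells (Homo sapiens) for inhibition, read by sulforhodamine B assay, with a stated time of 48 h (a lower number here means a stronger inhibitor of growth, a higher number a weaker inhibitor of growth), the highest of the two numbers recorded. Compound 2 `COc1cc(-c2nn(-c3cccc(NC(=O)c4ccccc4)c3)cc2-c2ccncc2)ccc1Cl` gives 1110 nM, and the step of a 1.2-fold lower number from compound 1 to compound 2 (0.08 log units; within the scatter) shows that swapping the group on the carbonyl carbon barely moves the result.

Compound 3 `O=C(Nc1cccc(-n2cc(-c3ccncc3)c(-c3ccc(Cl)c(O)c3)n2)c1)Nc1ccc(Cl)c(C(F)(F)F)c1` is compound 1 with a single change: hydrogen in place of methyl on an oxygen on an aromatic ring. Going by the values given here, no measured pair touches this oxygen, so nothing recorded speaks directly to it. Among the compounds with values here, the one measured step concerns the carbonyl carbon on the other side of the molecule, and it stayed within the scatter, so the starting point is simply the value of compound 1.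

With no evidence either way, compound 3 is expected to give about 1300 nM, with a range from 450 nM to 3800 nM. The step of a 1.0-fold lower number from compound 1 to compound 3 (0.01 log units; within the scatter) that this estimate implies is expected to lie within the scatter.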

Compound 3, concentration for 50% growth inhibition: 797 nM
Estimate against measurement, compound 3: 1.6-fold (0.21 log units) above; the measured number falls inside the stated range.
By their numbers in this assay, from the lowest: compounds 3, 2 and 1 (each within the scatter of the next).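

Going from methoxy to hydroxy on the 4-chloro-3-methoxyphenyl ring gives a 1.7-fold lower number from compound 1 to compound 3 (0.22 log units; within the scatter) in this assay, so this first look at the oxygen shows that its methyl can give way to hydrogen without a change that stands clear of the usual variation between repeats. Together with the earlier step at the carbonyl carbon, this means that neither of the two places changed so far has produced a clear difference in this assay. Nothing measured here bears on why the methyl and the hydrogen give such similar numbers.

As far as these compounds go, what remains open is whether this oxygen would accept something larger, such as an ethyl group or a longer chain. From the compounds shown here alone, it is also open whether an amine in place of the hydroxy would leave the number just as unmoved.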